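From pyridin-4-yl to pyridin-3-yl: a cytotoxicity question

The source may hold more compounds than are shown below. What is called first, only, known or untested is meant among the compounds shown, and "the series" means these compounds.

Compound 1 (`c1ccc(Cn2cncc2CNc2cccc(-c3ccncc3)c2)cc1`) has been tested in a toxicity assay on NIH3T3 cells (Mus musculus) for cytotoxicity, read by resazurin assay; on this read-out lower numbers stand for an effect already at smaller amounts and higher numbers for an effect only at larger amounts of compound. Compound 1 gives > 1000 nM, which is a limit of the assay and not an exact number. Compound 2 (`CCCC(=O)c1ccc(NCc2cncn2Cc2ccc(-c3ccccc3)cc2)cc1-c1ccccc1`), a larger molecule, also gives only a limit, > 10000 nM. So neither result offers an exact value to start from.

The next compound, compound 3 (`c1ccc(Cn2cncc2CNc2cccc(-c3cccnc3)c2)cc1`), has the same atoms as compound 1, joined differently: pyridin-3-yl in place of pyridin-4-yl on an aromatic carbon. In other words, pyridin-3-yl stands in place of pyridin-4-yl on an aromatic carbon. Among the measured compounds shown here, no measured pair shows what such a swap does in this assay, so no change beyond the usual scatter is expected. The estimated step is a step that the limit leaves unreadable from compound 1 to compound 3. For compound 3 the expected value is 1500 nM, with an estimated range from 700 nM to 5000 nM.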

Compound 3, half-maximal effective concentration: > 1000 nM
Compound 3: no number, only a limit; the forecaster's own chance of this, stated with the estimate: 70%; the middle value does not contradict the limit.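

In this assay, among the compounds shown here, compound 1 and compound 3 each give only a limit of the assay, not an exact number, so no step between them can be read. The compounds shown leave open whether pyridin-3-yl in place of pyridin-4-yl changes cytotoxicity at all, and at what concentration either compound would show an effect.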